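Vinyl to ethynyl on the shared core

The compounds below may be only part of what the source reports. "The series", "measured", "known", "first", "only" and "open" are said of these compounds alone.

Compound 1 `C=Cc1nc2ccccc2s1` gives > 40000 nM in a functional assay on HCT-116 cells (Homo sapiens) for cytotoxicity, with a stated time of 3 days (on this read-out lower numbers stand for stronger inhibition and higher numbers for weaker inhibition), and this value is a limit, not a number. Compound 2 `C#Cc1nc2ccccc2[se]1` gives 25000 nM in this assay. Compound 3 `C#Cc1nc2ccccc2s1` has ethynyl in place of vinyl on an aromatic carbon. Within the data shown here, no measured step covers this change. Compound 2, at 25000 nM, supports the expectation of a modest shift towards stronger inhibition. The expected size of this shift is an at least 2.0-fold lower number from compound 1 to compound 3 (0.30 log units; that floor lies within the scatter). For compound 3 the estimated value is 20000 nM, with an expected range of 7000 nM to 40000 nM.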

Compound 3, half-maximal inhibitory concentration: 19600 nM
The estimate for compound 3 lay 1.0-fold (0.01 log units) above the measured number, within the range that was stated.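

Ethynyl in place of vinyl on an aromatic carbon, next to the ring nitrogen and next to the ring sulfur, gives an at least 2.0-fold lower number from compound 1 to compound 3 (0.30 log units; that floor lies within the scatter). On the shared core, compound 3 gives a measured number in this assay, 19600 nM. The step stays a floor because compound 1 carries only a limit: the limit of > 40000 nM in this assay, at which 1 of the 3 values shown sits.

From the compounds shown here alone, the true size of the step from vinyl to ethynyl remains open. So does the response at this position to an amine, a carboxylic acid or a longer chain.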